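From 4-fluorophenyl to 3-fluorophenyl: one antiproliferative step

The compounds below may be only part of what the source reports. "The series", "measured", "known", "first", "only" and "open" are said of these compounds alone.

Compound 1 `COC(=O)/C(=C/c1ccccc1)CN1C(=O)[C@@H](OC)[C@H]1c1ccc(F)cc1` gives 15600 nM
Compound 2 `COc1ccc(OC)c([C@@H]2[C@H](OC)C(=O)N2C/C(C#N)=C/c2ccccc2)c1` has no result reported

Going by the values given here, in a functional assay on MCF7 cells (Homo sapiens) for antiproliferative activity, read by MTT assay, with a stated time of 48 h (a lower number here means a stronger inhibitor, a higher number a weaker inhibitor), compound 1 gives 15600 nM as the only number available, so it cannot be ranked against any other compound. Compound 3 `COC(=O)/C(=C/c1ccccc1)CN1C(=O)[C@@H](OC)[C@H]1c1cccc(F)c1` has not yet been measured. It carries 3-fluorophenyl in place of 4-fluorophenyl on a saturated ring carbon and otherwise keeps the core of compound 1 unchanged. Among the compounds with values here, no measured step offers a guide to this change, so the expectation rests on compound 1 at 15600 nM alone. No shift beyond the usual scatter is expected, and neither direction is favoured. The estimated step is a 1.0-fold lower number from compound 1 to compound 3 (0.02 log units; within the scatter) and stays within that scatter. Compound 3 is estimated to give 15000 nM in this assay with an expected range from 6000 nM at the low end to 40000 nM at the high end.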

Compound 3, half-maximal inhibitory concentration: 13700 nM
Compound 3: the middle estimate sits 1.1-fold (0.04 log units) above what was measured, within the range that was stated.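

Until now, compound 1 stood alone, and nothing showed how this position responds to a change. Setting 3-fluorophenyl in place of 4-fluorophenyl on a saturated ring carbon, next to the ring nitrogen of the four-membered ring, gives a 1.1-fold lower number from compound 1 to compound 3 (0.06 log units; within the scatter) in this assay. Moving the fluorine around the phenyl ring therefore makes no difference that can be resolved in this assay, and this single pair gives the first reading for the position. No supporting data bear on why the two compounds read alike.

The compounds shown leave open whether this holds beyond fluorine, for example with an amine or a carboxylic acid on that phenyl ring. They also do not show what a longer chain in place of the phenyl ring on the same ring carbon would do.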